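Cytotoxicity notes: amine to thioether exchange

The compounds below may be only part of what the source reports. "The series", "measured", "known", "first", "only" and "open" are said of these compounds alone.

Compound 2 `CC(C)CNc1nc(N)nc2c1ncn2/C=C1/CC1(CO)CO` is the reference point of this comparison. In an ADME assay on HFF cells (Homo sapiens) for cytotoxicity, with a stated time of 8 days (on this read-out lower numbers stand for higher toxicity in this test and higher numbers for lower toxicity in this test), compound 2 reports only a limit, > 300000 nM. Compound 1 `Nc1nc(NC2CC2)c2ncn(/C=C3/CC3(CO)CO)c2n1` carries cyclopropyl on the nitrogen on the aromatic ring in place of isobutyl; in this assay compound 1 likewise gives only a limit, > 300000 nM. Compound 3 `Nc1nc(NC2CCCC2)c2ncn(/C=C3/CC3(CO)CO)c2n1` carries cyclopentyl on that nitrogen; in this assay compound 3 also stands at a limit, > 300000 nM. The steps a step that the two limits leave unreadable from compound 1 to compound 2, a step that the two limits leave unreadable from compound 1 to compound 3 and a step that the two limits leave unreadable from compound 2 to compound 3 cannot be sized because every value rests at the limit of > 300000 nM in this assay, at which 3 of the 3 values shown sit.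

Compound 4 `Nc1nc(SC2CCCC2)c2ncn(/C=C3/CC3(CO)CO)c2n1` differs from compound 2 by cyclopentylsulfanyl in place of isobutylamino on an aromatic carbon. Among the measured compounds shown here, no measured step bears a readable size, and none covers the exchange of the amine nitrogen for a sulfur on this aromatic carbon, so the only guidance is that each variation here has so far left the read-out at the limit. Compound 4 is therefore expected to give 300000 nM, within 100000 nM to 1000000 nM. The step of a number no higher from compound 2 to compound 4 (the limit leaves the size open) is expected to be none beyond the scatter, with a further limit the most likely outcome.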

Compound 4, half-maximal cytotoxic concentration: > 300000 nM
Compound 4 gave a limit, no number; the forecaster's own chance of this, stated with the estimate: 80%; the middle value lies on the limit itself.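

The steps from compound 1, compound 2 and compound 3 to compound 4 cannot be read, because all four values in this assay are limits: the limit of > 300000 nM in this assay, at which 4 of the 4 values shown sit.

The compounds shown leave open whether exchanging the amine nitrogen for sulfur changes cytotoxicity at all.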